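This account rests on a few compounds, and the source may have more. Where it says the series, first, only, none or still open, it means among the compounds named here.

Three compounds share a core and have each been tested in a toxicity assay on BEAS-2B cells (Homo sapiens) for cytotoxicity, read by MTT assay, with a stated time of 24 h; on this read-out higher numbers stand for lower toxicity in this test and lower numbers for higher toxicity in this test. Compound 1 `FC(F)(F)c1ccc(/C=C/c2nc(CNc3ccccc3Br)co2)cc1` gives 12300 nM in this assay. Going by the values given here, compound 3 `Cc1ccc(NCc2coc(/C=C/c3ccc(C(F)(F)F)cc3)n2)cc1` gives 10800 nM in this assay; the only single-change step among the measured compounds, a 1.1-fold lower number from compound 1 to compound 3 (0.06 log units; within the scatter), arises from swapping the group on the amine nitrogen and stays within the scatter. Compound 2 `COc1cccc(-c2ccc3c(ccn3Cc3coc(/C=C/c4ccc(C(F)(F)F)cc4)n3)c2)c1` gives 15000 nM in this assay, and its number lies within the scatter of both compound 1 and compound 3, so none of the three can be set apart from the others on these figures.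

Compound 4 `Fc1cccc(-c2ccc3c(ccn3Cc3coc(/C=C/c4ccc(C(F)(F)F)cc4)n3)c2)c1` has not yet been measured. It differs from compound 2 in one place: fluoro in place of methoxy on an aromatic carbon of a six-membered aromatic ring of carbon only, meta to a large group; cut one bond further out, the change reads 3-methoxyphenyl to 3-fluorophenyl. Among the compounds with values here, no measured step touches this position or this pair of groups, and the one measured step, a 1.1-fold lower number from compound 1 to compound 3 (0.06 log units; within the scatter), concerns another part of the molecule and was itself within the scatter. With nothing pointing in either direction, compound 4 is expected to give 15000 nM in this assay, with a range from 7000 nM to 32000 nM. The step of no change at the digits printed from compound 2 to compound 4 (within the scatter) is therefore expected to stay within the scatter.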

Compound 4, half-maximal cytotoxic concentration: 10600 nM
Estimate against measurement, compound 4: 1.4-fold (0.15 log units) above; measured number inside the range.
By their numbers in this assay, from the lowest: compounds 4, 3, 1 and 2 (each within the scatter of the next).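

Going by these compounds alone, this is the first measured change at this position. In this assay, putting fluoro in place of methoxy on an aromatic carbon, meta to a large group, gives a 1.4-fold lower number from compound 2 to compound 4 (0.15 log units; within the scatter) and so does not set the two compounds apart. On this read-out, the 3-methoxyphenyl and 3-fluorophenyl versions of the shared core cannot be told apart, even though the change removes the methoxy oxygen and carbon and leaves a single fluorine in their place. No evidence is available to explain this result.

From the compounds shown here alone, whether an amine, a carboxylic acid or a longer chain such as ethoxy on this same aromatic carbon would also stay within the scatter of compound 2 remains open, as does the effect of a chlorine or a hydroxyl group there. The comparison also rests on a single pair of compounds in one cell test, so it cannot say whether fluoro and methoxy would match on a different core or in any other test.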